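Benzyl for 4-hydroxycyclohexyl: from compound 3 to compound 4

The source may hold more compounds than are shown below. What is called first, only, known or untested is meant among the compounds shown, and "the series" means these compounds.

In an ADME assay on HEK-293T cells (Homo sapiens) for cytotoxicity, read by CCK-8 assay, with a stated time of 48 h (on this read-out higher numbers stand for weaker inhibition and lower numbers for stronger inhibition), compound 1 (`O=C(Nc1cccc([N+](=O)[O-])c1)N1CCN(S(=O)(=O)c2sccc2-c2ccccc2Oc2ccc(O)c(O)c2)CC1`) gives > 20000 nM, which is a limit of the assay and not a number. Compound 2 (`Cc1ccc(-c2ccsc2S(=O)(=O)NCCNC(=O)Nc2cc(C(F)(F)F)cc(C(F)(F)F)c2)c(Oc2ccc(O)c(O)c2)c1`) gives > 20000 nM, again only a limit. Within the data shown here, compound 3 (`O=C(NCCNS(=O)(=O)c1ccc(-c2ccccc2O[C@H]2CC[C@@H](O)CC2)s1)Nc1cc(C(F)(F)F)cc(C(F)(F)F)c1`) gives 14100 nM, the only true number so far in this assay.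

Compound 4 (`O=C(NCCNS(=O)(=O)c1ccc(-c2ccccc2OCc2ccccc2)s1)Nc1cc(C(F)(F)F)cc(C(F)(F)F)c1`) carries benzyl in place of 4-hydroxycyclohexyl on an oxygen on an aromatic ring. Among the measured compounds shown here, no measured pair covers this exchange, so the data give no direction for it. For the measured compounds named here, the only anchor is compound 3 at 14100 nM. The estimated step runs a 1.0-fold lower number from compound 3 to compound 4 (0.00 log units; within the scatter), with no shift expected beyond the usual scatter in either direction. Compound 4 is estimated at 14000 nM, with an expected range of 6000 nM to 28000 nM. A report as a limit rather than a number is also expected to be a real possibility.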

Compound 4, half-maximal inhibitory concentration: > 20000 nM
Compound 4: no number, only a limit; the forecaster's own chance of this, stated with the estimate: 35%; at least 1.4-fold (0.15 log units) between middle value and limit.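

In this assay, among these compounds, the exchange of 4-hydroxycyclohexyl for benzyl on the oxygen on the aromatic ring gives the first step at this position: an at least 1.4-fold higher number from compound 3 to compound 4 (0.15 log units; that floor lies within the scatter). Compound 4 gives > 20000 nM, which is a limit of the assay and not a number. The direction of the step is therefore shown, but its true size is not, and compound 3 remains the only compound with a true number: the limit of > 20000 nM in this assay, at which 3 of the 4 values shown sit.

This single pair exchanges the non-aromatic ring for an aromatic one and also removes the hydroxyl, so the two changes cannot be separated. Open questions are whether a plain cyclohexyl on this oxygen would separate them, and whether an amine in place of the hydroxyl on the cyclohexyl would give a number in this assay.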